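Cytotoxicity notes on an amide-linked triazine series

The source may report more compounds than this note shows. Statements on the series, on what has been measured and on what is new or still open speak of the compounds shown alone.

Measured in an ADME assay on MT4 cells (Homo sapiens) for cytotoxicity, read by MTT assay; a higher number here means that more compound is tolerated, a lower number that less compound is tolerated:
- compound 1 `O=C(CSc1nncnc1-c1ccccc1Cl)Nc1ccccc1`: 127000 nM
- compound 2 `Cc1ccccc1NC(=O)CSc1nncnc1-c1ccccc1Cl`: 142000 nM
- compound 3 `Cc1ccccc1NC(=O)CSc1nncnc1-c1cccc2ccccc12`: 158000 nM

All three values lie within the scatter of one another. Compound 2 and compound 1 share one core and differ by hydrogen in place of methyl on an aromatic carbon; that change gave a 1.1-fold lower number from compound 2 to compound 1 (0.05 log units; within the scatter). Compound 3 carries a different core; the difference between the two cores is not broken down here.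

Compound 4 `O=C(CSc1nncnc1-c1cccc2ccccc12)Nc1ccccc1` is not yet measured. It differs from compound 3 by hydrogen in place of methyl on an aromatic carbon, the same kind of change as from compound 2 to compound 1, at a place described in the same words. Because a 1.1-fold lower number from compound 2 to compound 1 (0.05 log units; within the scatter) stayed within the scatter, a step of similar size, a 1.1-fold lower number from compound 3 to compound 4 (0.04 log units; within the scatter), is expected in this assay. The estimate for compound 4 is 145000 nM, between 90000 nM and 250000 nM.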

Compound 4, half-maximal cytotoxic concentration: 154000 nM
Beside the measured number, compound 4's estimate is 1.1-fold (0.03 log units) below it; the measured number falls inside the stated range.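

Hydrogen in place of methyl on an aromatic carbon gave a 1.0-fold lower number from compound 3 to compound 4 (0.01 log units; within the scatter) in this assay and so behaved alike on the two cores, with no difference that can be told from the scatter: the same change on two cores in this assay, a 1.1-fold lower number (0.05 log units; within the scatter) from compound 2 to compound 1 and a 1.0-fold lower number (0.01 log units; within the scatter) from compound 3 to compound 4, 1.1-fold (0.04 log units) apart, within the scatter of two such steps.
Across these two pairs, going from 2-methylphenyl to phenyl can be carried from one core to the other without a readable shift in this assay.
Two pairs do not show that this holds on further cores or in other assays, and neither step gives a readable effect of the methyl group.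

Still open, on these data alone, is whether a larger or charged group at the same place, such as an amine or a carboxylic acid, would also stay within the scatter.
As far as these compounds go, a longer alkyl chain there is equally open.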